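A few compounds are considered here, and "the series" means these few. Any claim that something is new, unique, unknown or untested is made for them only; others in the source may bear on it.

Measured compounds in a functional assay on PC-12 cells (Rattus norvegicus) for cytotoxicity, read by MTT assay, with stated times of 2 h and 24 h, tested at 10 uM; on this read-out lower numbers stand for a weaker effect and higher numbers for a stronger effect at the one concentration tested:
compound 1, `Oc1cc(C(F)(F)F)ccc1-c1nc(-c2ccccc2O)n(-c2ccc(Cl)cc2)n1`, gives 96.1%
compound 2, `Oc1cc(C(F)(F)F)ccc1-c1nc(-c2ccccc2O)n(-c2ccc(Br)cc2)n1`, gives 100%
compound 3, `Oc1cc(C(F)(F)F)ccc1-c1nc(-c2ccccc2O)n(-c2ccccc2F)n1`, gives 100%

Compound 3 stands level with compound 2 at the digits reported, the two of them giving the highest of the three numbers; the remaining gap in the set is a number 3.9 percentage points higher from compound 1 to compound 3 (within the scatter), so the three compounds cannot be told apart on this read-out. All three steps on the aryl group at the aromatic nitrogen, a number 3.9 percentage points higher from compound 1 to compound 2 (within the scatter), a number 3.9 percentage points higher from compound 1 to compound 3 (within the scatter) and no change at the digits printed from compound 2 to compound 3 (within the scatter), stay within the scatter, and all three values sit close to the top of the scale.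

Compound 4, `COc1ccccc1-n1nc(-c2ccc(C(F)(F)F)cc2O)nc1-c1ccccc1O`, differs from compound 3 by methoxy in place of fluoro on an aromatic carbon. The change sits on an aromatic carbon of a six-membered aromatic ring of carbon only, ortho to a large group, on the same aryl group at the aromatic nitrogen that the three measured steps vary. Among the measured compounds shown here, none of the measured steps exchanges fluoro for methoxy, so this exact change has no precedent; what is known is that every variation so far on this ring has left the read-out within the scatter, near its ceiling. Compound 4 is therefore expected to show a step of a number 3 percentage points lower from compound 3 to compound 4 (within the scatter), that is, no change beyond the scatter. The estimate for compound 4 is 97%, within a range of 85% to 100%.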

Compound 4, a percentage reported as activity, at one concentration (the size of the read-out at that concentration, not a potency): 96.2%
Beside the measured number, compound 4's estimate is 0.8 percentage points above it; low and high end bracket the measured number.
By their numbers in this assay, from the lowest: compounds 1, 4, 2 and 3 (each within the scatter of the next).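

Among the compounds shown here, the series now holds a first exchange on an aromatic carbon ortho to a large group, and in this assay methoxy in place of fluoro gives a number 3.8 percentage points lower from compound 3 to compound 4 (within the scatter), so a substituent of 2 heavy atoms and one of 1 heavy atom cannot be told apart at this place. The exchanges of the whole aryl group on the aromatic nitrogen read the same way, with a number 3.8 percentage points lower from compound 2 to compound 4 (within the scatter) and a number 0.1 percentage points higher from compound 1 to compound 4 (within the scatter), so 2-methoxyphenyl cannot be separated from 4-bromophenyl or 4-chlorophenyl on this read-out. No measurement at hand explains why these exchanges leave the read-out within the scatter.

All four values lie near the top of the scale at the one concentration tested, so this assay leaves open whether these aryl groups would separate at lower concentrations. Also open, as far as these compounds go, is whether an aminomethyl group, a carboxylic acid or a longer alkoxy chain such as butoxy at this place would give a step beyond the scatter, and what the two hydroxyl groups and the trifluoromethyl group of the shared core contribute, since they are common to all four compounds.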